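Shortening the chain in a phenyl pyridazinone thioamide series

The source may report more compounds than this note shows. Statements on the series, on what has been measured and on what is new or still open speak of the compounds shown alone.

Measured compounds:
compound 1, `N=C(S)CCCCN1N=C(c2ccccc2)CCC1=O`, in a functional assay on the whole organism (stomach) with Rattus norvegicus as the target (a higher number here means that more compound is needed for the effect, a lower number that less compound is needed), compound 1 gives 100 mg/kg;
compound 2, `CC(Cn1nc(-c2ccccc2)ccc1=O)C(=N)S`, compound 2 gives 28.1 mg/kg;
compound 3, `N=C(S)CCn1nc(-c2ccccc2)c2ccccc2c1=O`, compound 3 gives 66.5 mg/kg.

Among these three, compound 1 has the highest number in this assay. Compound 3 stands nearest to it, and the gap between the two falls within the usual scatter, so no order between compound 1 and compound 3 can be read from the data. Compound 2 stands furthest away, with a number lower than compound 1 by a gap that is beyond the scatter.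

Compound 4, `N=C(S)CCCN1N=C(c2ccccc2)CCC1=O`, is the next compound to be measured in this assay. It differs from compound 1 by a group of 3 heavy atoms (1 carbon, 1 nitrogen, 1 sulfur; no ring) in place of a group of 4 heavy atoms (2 carbon, 1 nitrogen, 1 sulfur; no ring), on a saturated chain carbon, three bonds along the chain from an amide-type nitrogen in a ring. Going by the values given here, no pair of measured compounds differs in this one place alone, so no measured step speaks to it directly. The change is small in size, and the expectation is that the step of a 1.3-fold lower number from compound 1 to compound 4 (0.10 log units; within the scatter) stays within the scatter. Compound 4 is therefore estimated at 80 mg/kg in this assay, with a range from 30 mg/kg to 200 mg/kg.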

Compound 4, dose for half-maximal effect: 100 mg/kg
Compound 4: middle estimate off by 1.3-fold (0.10 log units), on the low side; the range from low to high includes it.
By their numbers in this assay, from the lowest: compound 2; then compounds 3, 1 and 4 (each within the scatter of the next).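

In this assay, placing a group of 3 heavy atoms where a group of 4 heavy atoms stood, on a saturated chain carbon, three bonds along the chain from an amide-type nitrogen in a ring, gives no change at the digits printed from compound 1 to compound 4 (within the scatter). Going by these compounds alone, this is the first step measured at this place, and it shows that this one change to the chain, with the core of compound 1 kept, does not separate the two compounds in this whole-animal read-out. Nothing available explains this result.

A longer chain at this place remains untested among the compounds shown, and so does a still shorter one. Also open, as far as these compounds go, is whether a carboxylic acid or an amine in place of the thioamide group would move the number beyond the scatter.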